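The source may report more compounds than this note shows. Statements on the series, on what has been measured and on what is new or still open speak of the compounds shown alone.

Measured in an assay on isolated protein (Bos taurus) for inhibition of geranylgeranyl transferase type-1 subunit beta (Homo sapiens); on this read-out higher numbers stand for weaker inhibition and lower numbers for stronger inhibition:
- compound 1 `Cn1cncc1C(OCc1nc(N2CCC(C(N)=O)CC2)c(C#N)cc1-c1cccc(Cl)c1)c1ccc(C#N)cc1`: 2100 nM
- compound 2 `Cn1cncc1C(OCc1ccc(C#N)cc1-c1cccc(Cl)c1)c1ccc(C#N)nc1`: 8620 nM
- compound 3 `Cn1cncc1C(OCc1ccc(C#N)cc1-c1cc(F)cc(F)c1)c1ccc(C#N)nc1`: > 10 nM, which is a limit of the assay and not a number (the limit of > 10 nM in this assay, at which 1 of the 3 values shown sits).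

Among the two numbers, compound 1 has the lowest; compound 2 lies higher, beyond the scatter. Compound 4 `CN1CCN(c2nc(COC(c3ccc(C#N)cc3)c3cncn3C)c(-c3cccc(Cl)c3)cc2C#N)CC1` differs from compound 1 in one place: 4-methylpiperazin-1-yl in place of 4-carbamoylpiperidin-1-yl on an aromatic carbon. Among the measured compounds shown here, the only measured step, a step that the limit leaves unreadable from compound 2 to compound 3, changes a different group and its size cannot be read, so no measured step bears on this change. For compound 4 the expected step is therefore a 1.2-fold higher number from compound 1 to compound 4 (0.08 log units; within the scatter), with a wide range. Compound 4 is estimated at 2500 nM, between 600 nM and 10000 nM.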

Compound 4, half-maximal inhibitory concentration: 2400 nM
Compound 4: the middle estimate sits 1.0-fold (0.02 log units) above what was measured, and the stated range covers the measured number.
By their numbers in this assay, from the lowest: compounds 1 and 4 (each within the scatter of the next); then compound 2.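

In this assay, placing 4-methylpiperazin-1-yl instead of 4-carbamoylpiperidin-1-yl on the aromatic carbon next to the ring nitrogen gives a 1.1-fold higher number from compound 1 to compound 4 (0.06 log units; within the scatter) on the core of compound 1. This position therefore accepts a ring without a hydrogen-bond donor and with fewer heavy atoms, and the two compounds cannot be told apart here. Nothing measured here explains why these two groups read alike. Still open, from the compounds shown here alone, is whether a morpholine ring or a simple dimethylamino group at this position would read the same, or whether either would give stronger inhibition.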